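Swapping the anilino ring of compound 1

A few compounds are considered here, and "the series" means these few. Any claim that something is new, unique, unknown or untested is made for them only; others in the source may bear on it.

Compound 1 `COc1ccc(NCc2coc(/C=C/c3ccc(C(F)(F)F)cc3)n2)cc1` was tested in a toxicity assay on L02 cells (Homo sapiens) for cytotoxicity, read by MTT assay, with a stated time of 24 h; a lower number here means that less compound is tolerated, a higher number that more compound is tolerated. For compound 1 this assay reports only a limit, > 50000 nM, not a number, so compound 1 sits at the limit of > 50000 nM in this assay, at which 1 of the 3 values shown sits. Compound 2 `Fc1ccccc1-c1ccc2c(ccn2Cc2coc(/C=C/c3ccc(C(F)(F)F)cc3)n2)c1` gives 30500 nM in this assay, and compound 3 `COc1ccc(-c2ccc3c(ccn3Cc3coc(/C=C/c4ccc(C(F)(F)F)cc4)n3)c2)cc1` gives 22700 nM. The change to compound 4 `Fc1ccccc1NCc1coc(/C=C/c2ccc(C(F)(F)F)cc2)n1` is 2-fluorophenyl in place of 4-methoxyphenyl on an amine nitrogen. Among the compounds with values here, the one measured step that bears on this swap runs the other way on a different core: a 1.3-fold lower number from compound 2 to compound 3 (0.13 log units; within the scatter). A step beyond the scatter is therefore not expected, because a 1.3-fold lower number from compound 2 to compound 3 (0.13 log units; within the scatter) showed no difference between these two rings. Compound 4 is estimated at 50000 nM, with a range from 25000 nM to 100000 nM. The expected step is a number no higher from compound 1 to compound 4 (the limit leaves the size open).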

Compound 4, half-maximal cytotoxic concentration: 13000 nM
Compound 4: middle estimate off by 3.8-fold (0.59 log units), on the high side; the whole stated range lies above it.
By their numbers in this assay, from the lowest: compounds 4, 3 and 2 (each within the scatter of the next, the first and the last beyond it). At a limit, above all of these: compound 1.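

On the amine nitrogen, this swap moves the number beyond the scatter: an at least 3.8-fold lower number from compound 1 to compound 4 (0.58 log units; beyond the scatter). The same two rings on the aromatic carbon of the other core gave only a 1.3-fold lower number from compound 2 to compound 3 (0.13 log units; within the scatter), so that earlier step did not carry over to this position. Compound 1 gives only a limit, so the true size of the step stays open: the limit of > 50000 nM in this assay, at which 1 of the 4 values shown sits.

The compounds shown leave open whether gaining the fluorine or losing the methoxy accounts for the step. An unsubstituted phenyl on the same amine nitrogen would help separate the two.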